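Benzyl on sulfur: one change, two cores

This account rests on a few compounds, and the source may have more. Where it says the series, first, only, none or still open, it means among the compounds named here.

Measured so far:
compound 1, `OC[C@H]1O[C@@H](n2cnc3c(S)nccc32)C[C@@H]1O`: < 5%
compound 2, `OC[C@H]1O[C@@H](n2cnc3c(SCc4ccccc4)nccc32)C[C@@H]1O`: 11%
compound 3, `OC[C@H]1OC(n2cnc3c(S)nccc32)[C@H](O)[C@@H]1O`: < 5%

All three were run in a functional assay on EL4 cells (Mus musculus) for inhibition, tested at 100 uM; on this read-out higher numbers stand for more inhibition at the one concentration tested (going by the name of the read-out) and lower numbers for less inhibition. For compound 1 the value < 5% is a limit of the assay, not a number. For compound 3 the value < 5% is likewise a limit. Compound 2 gives 11%. The change from compound 1 to compound 2 is benzyl in place of hydrogen on a sulfur; it made a number at least 6 percentage points higher from compound 1 to compound 2 (that floor lies within the scatter). Going by these compounds, the floor of that step is set by the limit of < 5% in this assay, at which 2 of the 3 values shown sit, so its true size stays open.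

Compound 4, `OC[C@H]1OC(n2cnc3c(SCc4ccccc4)nccc32)[C@H](O)[C@@H]1O`, is not yet measured. It differs from compound 3 by benzyl in place of hydrogen on a sulfur, the same change at the same place as from compound 1 to compound 2. How the core of compound 3 differs from the core of compound 1 is not broken down here.

Within the data shown here, the only precedent for this change starts from a limit. The expected step of a number at least 5 percentage points higher from compound 3 to compound 4 (that floor lies within the scatter) is therefore placed beside a number at least 6 percentage points higher from compound 1 to compound 2 (that floor lies within the scatter), with wide room on either side. Compound 4 is estimated at 10% in this assay, expected to fall between 3% and 20%.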

Compound 4, a percentage reported as inhibition, at one concentration (the size of the read-out at that concentration, not a potency): 30%
Estimate against measurement, compound 4: 20 percentage points below; measured number above the stated range.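

In this assay, benzyl in place of hydrogen on a sulfur gives a number at least 25 percentage points higher from compound 3 to compound 4 (beyond the scatter), so on the core of compound 3 the change raises the read-out beyond the scatter. Set beside the same change on the core of compound 1, this does not show that the size of the step carries over unchanged, nor that one core gains more than the other: the same change on two cores in this assay, a number at least 6 percentage points higher (that floor lies within the scatter) from compound 1 to compound 2 and a number at least 25 percentage points higher (beyond the scatter) from compound 3 to compound 4; the limit leaves it open whether they differ The true size of either step stays unknown, since each starts from a limit rather than a number: the limit of < 5% in this assay, at which 2 of the 4 values shown sit.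

The compounds shown leave open whether the rise belongs to benzyl itself or would also come with another group on the sulfur, such as a methyl, a longer chain or a chain ending in an amine. Also open is whether a carboxylic acid on the aromatic ring of the benzyl would keep the rise, and how any of these compounds would rank as to potency, as the read-out comes from one concentration only.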